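The source may report more compounds than this note shows. Statements on the series, on what has been measured and on what is new or still open speak of the compounds shown alone.

Measured so far in a functional assay on Huh-5-2 cells (Homo sapiens), read by MTT assay; on this read-out lower numbers stand for higher toxicity in this test and higher numbers for lower toxicity in this test:
- compound 1 `O=C(O)c1ccc(-c2ccc(Cl)cc2COc2ccc(-c3nc4cc(C(=O)O)ccc4n3C3CCCCC3)cc2)cc1`: > 50000 nM
- compound 2 `O=C(O)c1ccc2c(c1)nc(-c1ccc(OCc3ccccc3-c3ccc(Cl)cc3)cc1)n2C1CCCCC1`: 25000 nM
- compound 3 `CCCNC(=O)c1ccc(-c2ccc(Cl)cc2)c(COc2ccc(-c3nc4cc(C(=O)O)ccc4n3C3CCCCC3)c(F)c2)c1`: 24000 nM

The result of compound 1 is a limit of the assay and not a number, > 50000 nM. Compound 3 gives 24000 nM and compound 2 gives 25000 nM, and these two values lie within the usual scatter of each other.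

The next compound to be tested is compound 4 `O=C(O)c1ccc2c(c1)nc(-c1ccc(OCc3cc(C(=O)N4CCC(O)CC4)ccc3-c3ccc(Cl)cc3)cc1F)n2C1CCCCC1`. It differs from compound 3 in one place, with 4-hydroxypiperidin-1-yl in place of propylamino on a carbonyl carbon.

Going by the values given here, no two measured compounds differ in one place only, so no measured step guides this change. The expectation therefore starts from compound 3 at 24000 nM, and no step beyond the scatter is expected in this assay. The expected change is a 1.3-fold higher number from compound 3 to compound 4 (0.10 log units; within the scatter). For compound 4 the estimated value is 30000 nM, with an expected range of 14000 nM to 50000 nM.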

Compound 4, half-maximal cytotoxic concentration: 26000 nM
For compound 4 the middle estimate is 1.2-fold (0.06 log units) above the measured one, and the stated range covers the measured number.
By their numbers in this assay, from the lowest: compounds 3, 2 and 4 (each within the scatter of the next). At a limit, above all of these: compound 1.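

In this assay, going by these compounds alone, the change on the carbonyl carbon gives a 1.1-fold higher number from compound 3 to compound 4 (0.03 log units; within the scatter) and is the only step that can be read so far. At this place, then, an open propylamino chain and the larger 4-hydroxypiperidin-1-yl, with its six-membered non-aromatic ring, give values that cannot be told apart in this test. Compound 1 remains the only result that is a limit and not a number, and compound 4 does not join it: the limit of > 50000 nM in this assay, at which 1 of the 4 values shown sits.

From the compounds shown here alone, whether a basic amine such as piperazine, a carboxylic acid or a longer alkyl chain on the same carbonyl carbon would give a step beyond the scatter stays open. This one step also cannot show whether the same swap would read alike on a different core.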